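The source may hold more compounds than are shown below. What is called first, only, known or untested is meant among the compounds shown, and "the series" means these compounds.

Compound 2 `COc1ccc(NC(=S)Nc2ccc3[nH]ccc3c2)cc1` holds the lowest of the two numbers in an assay on cells for inhibition of Amine oxidase [flavin-containing] B (Homo sapiens), read by spectrophotometry (a higher number here means a weaker inhibitor, a lower number a stronger inhibitor), giving 37000 nM. Its nearest neighbour is compound 1 `S=C(Nc1ccccc1)Nc1ccc2[nH]ccc2c1`, which in this assay gives 60000 nM; the step of a 1.6-fold lower number from compound 1 to compound 2 (0.21 log units; within the scatter) stays within the scatter. Compound 3 `S=C(Nc1ccc(Br)cc1)Nc1ccc2[nH]ccc2c1` differs from compound 2 by bromo in place of methoxy on an aromatic carbon. Going by the values given here, the one measured step, from hydrogen to methoxy at the same place, was small, so a further exchange there is expected to bring no step beyond the scatter, roughly a 1.1-fold higher number from compound 2 to compound 3 (0.03 log units; within the scatter). Compound 3 is therefore estimated at 40000 nM, between 15000 nM and 100000 nM.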

Compound 3, half-maximal inhibitory concentration: 58000 nM
Compound 3: middle estimate off by 1.5-fold (0.16 log units), on the low side; measured number inside the range.
By their numbers in this assay, from the lowest: compounds 2, 3 and 1 (each within the scatter of the next).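

Bromo on this aromatic carbon gives a 1.6-fold higher number from compound 2 to compound 3 (0.20 log units; within the scatter) when it replaces methoxy and a 1.0-fold lower number from compound 1 to compound 3 (0.01 log units; within the scatter) when it replaces hydrogen in this assay at this place. Hydrogen, methoxy and bromo therefore all stand within the scatter of one another, so a second kind of group, with no hydrogen-bond acceptor, again moves the number by no more than the scatter. Nothing available explains why these numbers stay so close.

On these data alone, it remains open whether an amine or a carboxylic acid at this place would move the number beyond the scatter. As far as these compounds go, it also remains open whether a change elsewhere on the shared core would do so.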